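The compounds below may be only part of what the source reports. "The series", "measured", "known", "first", "only" and "open" are said of these compounds alone.

Measured compounds in the series so far:

compound 1, `COc1ccc(C2SCC(=O)N2c2ccc3c(C)cc(=O)[nH]c3c2)cc1`, 21.4%
compound 2, `COc1ccc(C2SCC(=O)N2c2ccc3c(C)cc(=O)[nH]c3c2)cc1OC`, 20.6%
compound 3, `Cc1cc(=O)[nH]c2cc(N3C(=O)CSC3c3ccc([N+](=O)[O-])cc3)ccc12`, 25.2%

All three numbers come from a functional assay on the whole organism (strain albino) for inhibition, with Rattus norvegicus as the target, read by paw edema, with stated times of 1 h and 3 h, at a dose of 100 mg/kg by the oral route; on this read-out higher numbers stand for more inhibition at the one dose given (going by the name of the read-out) and lower numbers for less inhibition. Compound 3 stands level with the other two: the step of a number 3.8 percentage points higher from compound 1 to compound 3 (within the scatter) and the step of a number 0.8 percentage points lower from compound 1 to compound 2 (within the scatter) both fall within the scatter, so this read-out does not separate compound 1, compound 2 and compound 3 from one another at the dose used.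

Compound 4 is `Cc1cc(=O)[nH]c2cc(N3C(=O)CSC3/C=C/c3ccccc3)ccc12`. It differs from compound 3 by 2-phenylethenyl in place of 4-nitrophenyl on a saturated ring carbon. Going by the values given here, the two measured steps concern only the methoxy and nitro substituents on the aromatic ring carried by the saturated ring carbon; neither of them bears directly on the exchange of a 4-nitrophenyl group for a 2-phenylethenyl group, so the change in compound 4 has no close precedent in the data. What the series does show is that three different groups on the saturated ring carbon all left the read-out within the scatter, and the same is expected for compound 4: the step of a number 3.2 percentage points lower from compound 3 to compound 4 (within the scatter) is expected to stay within the scatter, with no direction worth naming. For compound 4 an inhibition of 22% is estimated, in a range from 11% to 33%.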

Compound 4, a percentage reported as inhibition, in the whole organism at one dose (the size of the read-out at that dose, not a potency): 20.8%
Beside the measured number, compound 4's estimate is 1.2 percentage points above it; the measured number falls inside the stated range.
By their numbers in this assay, from the lowest: compounds 2, 4, 1 and 3 (each within the scatter of the next).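

In this assay compound 4 is the only one of the four in which the aromatic ring is not bonded directly to the saturated ring carbon, since 2-phenylethenyl carries it on a double bond outside the ring, and the read-out still gives a number 4.4 percentage points lower from compound 3 to compound 4 (within the scatter) and a number 0.6 percentage points lower from compound 1 to compound 4 (within the scatter). The group entering at this position holds carbon only and has 0 hydrogen-bond acceptors, against 2 in the 4-nitrophenyl that leaves, so among these compounds neither a directly attached aromatic ring nor the nitro group is needed for a number of this size at the one dose given. No measurement is at hand that would explain the read-out at this position.

As far as these compounds go, all four groups on the saturated ring carbon contain a six-membered aromatic ring of carbon only, so it remains open how this read-out responds to an amine, a carboxylic acid or a longer saturated chain there. From the compounds shown here alone, it is also open whether any change at this position, or any change to the shared core, can move the read-out beyond the scatter.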